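From fluoro to methoxy on compound 1

This account rests on a few compounds, and the source may have more. Where it says the series, first, only, none or still open, it means among the compounds named here.

In a toxicity assay on cells (Macrophage, Mus musculus, strain BALB/c) for cytotoxicity, read by MTT assay (a higher number here means a weaker inhibitor, a lower number a stronger inhibitor), compound 1 `C=CCOc1cc(OC)c(C(=O)/C=C/c2ccc(F)cc2)c(OCC=C)c1` gives 13800 nM and compound 3 `COc1cc(O)cc(O)c1C(=O)/C=C/c1ccccc1Br` gives 14600 nM, two values within the scatter of each other, while compound 2 `COc1cc(O)cc(O)c1C(=O)/C=C/c1ccco1` gives the far higher 384000 nM. Compound 1 therefore sits level with compound 3 at the low end of the three numbers. Compound 4 `C=CCOc1cc(OC)c(C(=O)/C=C/c2ccc(OC)cc2)c(OCC=C)c1` is compound 1 with one change, methoxy in place of fluoro on an aromatic carbon, para to a large group, so that 4-fluorophenyl becomes 4-methoxyphenyl.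

Among the measured compounds shown here, the only measured step, a 26-fold lower number from compound 2 to compound 3 (1.42 log units; beyond the scatter), is large, but it replaces furan-2-yl with 2-bromophenyl in compounds that differ from compound 1 elsewhere as well. For the measured compounds named here, it bears on this change only loosely, and no measured step exchanges fluoro for methoxy. No shift beyond the scatter is therefore expected, and the estimated step is a 1.2-fold higher number from compound 1 to compound 4 (0.06 log units; within the scatter). For compound 4 the estimated value in this assay is 16000 nM, with an expected range from 6000 nM to 45000 nM.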

Compound 4, half-maximal inhibitory concentration: 18700 nM
For compound 4 the middle estimate is 1.2-fold (0.07 log units) below the measured one, and the stated range covers the measured number.
By their numbers in this assay, from the lowest: compounds 1, 3 and 4 (each within the scatter of the next); then compound 2.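

In this assay, methoxy in place of fluoro on an aromatic carbon, para to a large group, gives a 1.4-fold higher number from compound 1 to compound 4 (0.13 log units; within the scatter) and so shows that this place on the core of compound 1 accepts the exchange without a shift beyond the scatter. Among the compounds shown here, the earlier compounds offered no step at this place, since their one step exchanged furan-2-yl for 2-bromophenyl on a different core, so this is the first direct reading of 4-fluorophenyl to 4-methoxyphenyl. No measured evidence accounts for this result.

As far as these compounds go, whether an amine, a carboxylic acid or a longer chain at this same place would also stay within the scatter remains open. So does whether fluoro and methoxy read alike on the core shared by compound 2 and compound 3.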